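This account rests on a few compounds, and the source may have more. Where it says the series, first, only, none or still open, it means among the compounds named here.

In a functional assay on HT-29 cells (Homo sapiens) for inhibition, read by MTT assay, with a stated time of 48 h (a lower number here means a stronger inhibitor, a higher number a weaker inhibitor), compound 1 `COc1ccc(CSc2nnc(-c3cc(OC)c(OC)c(OC)c3)n2-c2ccc(OC)cc2)cc1` gives > 60000 nM, which is a limit. Compound 2 `COc1ccc(-n2c(SCC(=O)c3ccccc3)nnc2-c2cc(OC)c(OC)c(OC)c2)cc1` gives > 60000 nM, also a limit, and it sits at the limit of > 60000 nM in this assay, at which 2 of the 3 values shown sit. Compound 3 `COc1ccc(-n2c(SCC(=O)Nc3ccc(Cl)cc3)nnc2-c2cc(OC)c(OC)c(OC)c2)cc1` gives 58000 nM.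

Compound 4 `COc1cc(-c2nnc(SCC(=O)c3ccccc3)n2-c2ccc(N(C)C)cc2)cc(OC)c1OC` differs from compound 2 in one place, with dimethylamino in place of methoxy on an aromatic carbon. The measured steps change only the group carried by the sulfur, so none tests this swap. They read an at least 1.0-fold lower number from compound 1 to compound 3 (0.01 log units; that floor lies within the scatter) and an at least 1.0-fold lower number from compound 2 to compound 3 (0.01 log units; that floor lies within the scatter), while a step that the two limits leave unreadable from compound 1 to compound 2.

With so little to go on, only a small expected step toward a lower number seems fair: an at least 2.0-fold lower number from compound 2 to compound 4 (0.30 log units; that floor lies within the scatter). The reading may again be a limit. For compound 4 the estimated value is 30000 nM, with an expected range from 3000 nM to 60000 nM.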

Compound 4, half-maximal inhibitory concentration: 45200 nM
Compound 4: middle estimate off by 1.5-fold (0.18 log units), on the low side; measured number inside the range.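

Among the steps shown, only this one changes the aromatic group, 4-methoxyphenyl to 4-(dimethylamino)phenyl, rather than the group on the sulfur, and in this assay it reads an at least 1.3-fold lower number from compound 2 to compound 4 (0.12 log units; that floor lies within the scatter). The true size of this step stays unknown, because compound 2 gives only a limit: the limit of > 60000 nM in this assay, at which 2 of the 4 values shown sit.

Going by these compounds, whether the same swap would read alike with the (4-chlorophenyl)carbamoyl chain of compound 3 remains open. So does how a primary amine or a carboxylic acid would read in place of the dimethylamino group.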